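A few compounds are considered here, and "the series" means these few. Any claim that something is new, unique, unknown or untested is made for them only; others in the source may bear on it.

Working notes on the series.

Compound 1 `Cc1nc(N)c2c(-c3cccs3)cn([C@@H]3O[C@H](CO)[C@@H](O)[C@H]3O)c2n1` and compound 2 `Cc1nc(N)c2c(-c3ccco3)cn([C@@H]3O[C@H](CO)[C@@H](O)[C@H]3O)c2n1` share one core and differ only in the five-membered ring on it; compound 3 `Nc1nc2c(c(-c3ccco3)cn2[C@@H]2O[C@H](CO)[C@@H](O)[C@H]2O)c(=O)[nH]1` and compound 4 `Nc1nc2c(c(-c3cccs3)cn2[C@@H]2O[C@H](CO)[C@@H](O)[C@H]2O)c(=O)[nH]1` share a second core and differ in the same way. How the two cores differ is not broken down here.

In a functional assay on CCRF-CEM cells (Homo sapiens), read by MTT assay, with a stated time of 72 h (on this read-out higher numbers stand for weaker inhibition and lower numbers for stronger inhibition), compound 2 gives a limit of the assay, > 100000 nM, not a number. In this assay compound 1 also gives a limit, > 20000 nM. The change from compound 2 to compound 1 is thiophen-2-yl in place of furan-2-yl on an aromatic carbon, and because both values are limits the step that the two limits leave unreadable from compound 2 to compound 1 cannot be read; the two limits are the limit of > 100000 nM in this assay, at which 1 of the 3 values shown sits, and (the limit of > 20000 nM in this assay, at which 2 of the 3 values shown sit).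

In this assay compound 3 gives a limit, > 20000 nM, and not a number. Compound 4 is not yet measured. The change from compound 3 to compound 4 is thiophen-2-yl in place of furan-2-yl on an aromatic carbon, the same change as from compound 2 to compound 1, with the place described in the same words.

For the measured compounds named here, since the only earlier instance of this change joins two limits, no size of step can be carried over. The expectation for compound 4 is a step that the limit leaves unreadable from compound 3 to compound 4 of no readable size in this assay. Compound 4 is expected to sit near 50000 nM, with a range from 15000 nM to 200000 nM, and most likely to be reported only as a limit, as compound 3 was with > 20000 nM.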

Compound 4, half-maximal inhibitory concentration: > 20000 nM
Compound 4 ended at the assay's limit (the forecaster's own chance of this, stated with the estimate: 85%); the middle value is on the limit's open side.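

In this assay compound 4 gives > 20000 nM, a limit of the assay and not a number. With compound 3 also at a limit, the step from compound 3 to compound 4 cannot be read. The compounds shown leave open whether thiophen-2-yl or furan-2-yl, on either core, gives a measurable inhibitory concentration in this assay, and how far apart the two groups would then stand.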